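Amide aryl swap: hydroxy out, methyl in

A few compounds are considered here, and "the series" means these few. Any claim that something is new, unique, unknown or untested is made for them only; others in the source may bear on it.

Three compounds share one core and differ only in the aryl on the amide nitrogen. Compound 1 `COc1ccc2occ(C(=O)Nc3ccccc3)c(=O)c2c1` carries a plain phenyl; in an assay on cells for inhibition of Amine oxidase [flavin-containing] B (Homo sapiens), read by fluorescence and Amplex Red, using microsomes, with a stated time of 15 min (on this read-out higher numbers stand for weaker inhibition and lower numbers for stronger inhibition), compound 1 gives 41.8 nM. Compound 2 `COc1ccc2occ(C(=O)Nc3cccc(C)c3)c(=O)c2c1` carries a methyl on that ring, and in this assay compound 2 gives 21.8 nM; the step of a 1.9-fold lower number from compound 1 to compound 2 (0.28 log units; within the scatter) stays within the scatter. Compound 3 `COc1ccc2occ(C(=O)Nc3cccc(O)c3)c(=O)c2c1` carries a hydroxy instead, and in this assay compound 3 gives 114 nM, the highest number of the three; the steps of a 2.7-fold higher number from compound 1 to compound 3 (0.44 log units; beyond the scatter) and a 5.2-fold higher number from compound 2 to compound 3 (0.72 log units; beyond the scatter) both lie beyond the scatter.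

Compound 4 `COc1ccc2occ(C(=O)Nc3ccc(C)cc3)c(=O)c2c1` is not yet measured. The change is 4-methylphenyl in place of 3-hydroxyphenyl on an amide-type nitrogen. Among the compounds with values here, two measured steps bear on it: the hydroxy-for-methyl step a 5.2-fold higher number from compound 2 to compound 3 (0.72 log units; beyond the scatter), which this change reverses, though the entering group is 4-methylphenyl, and the methyl-for-hydrogen step a 1.9-fold lower number from compound 1 to compound 2 (0.28 log units; within the scatter), which shows the methyl itself moving the number little. Compound 4 is therefore expected to come down towards compound 1 and compound 2, because the step of a 5.2-fold higher number from compound 2 to compound 3 (0.72 log units; beyond the scatter) ran the other way. In this assay compound 4 is expected to give about 30 nM, between 12 nM and 80 nM. That estimate means an expected step of a 3.8-fold lower number from compound 3 to compound 4 (0.58 log units; beyond the scatter), a lower number beyond the scatter.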

Compound 4, half-maximal inhibitory concentration: 211 nM
For compound 4 the middle estimate is 7.0-fold (0.85 log units) below the measured one; measured number above the stated range.
By their numbers in this assay, from the lowest: compounds 2 and 1 (each within the scatter of the next); then compounds 3 and 4 (each within the scatter of the next).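

Where the methyl sits on the amide aryl decides the outcome: 4-methylphenyl in place of 3-methylphenyl gives a 9.7-fold higher number from compound 2 to compound 4 (0.99 log units; beyond the scatter), and against the plain phenyl the methyl of 4-methylphenyl gives a 5.0-fold higher number from compound 1 to compound 4 (0.70 log units; beyond the scatter), whereas the methyl of compound 2 stayed within the scatter of compound 1. Removing the hydroxy of 3-hydroxyphenyl therefore does not by itself restore the number, since 4-methylphenyl in its place gives a 1.9-fold higher number from compound 3 to compound 4 (0.27 log units; within the scatter), leaving these two aryl groups indistinguishable here. No data on hand explain the dependence on methyl placement.

Going by these compounds, whether a methoxy or an amine in the place the methyl holds in 4-methylphenyl would raise the number as well remains open. So does whether a hydroxy there would behave like the methyl.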